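Extending the indole nitrogen chain from ethyl to butyl

A few compounds are considered here, and "the series" means these few. Any claim that something is new, unique, unknown or untested is made for them only; others in the source may bear on it.

The series shares an indole glyoxylamide core bearing a methoxypyridine on the amide nitrogen. Compound 1 `CCn1cc(C(=O)C(=O)Nc2ccnc(OC)c2)c2ccccc21` gives 4180 nM in a functional assay on FaDu cells (Homo sapiens) for cytotoxicity, read by MTT assay, with a stated time of 72 h; a higher number here means that more compound is tolerated, a lower number that less compound is tolerated. Compound 2 `CCn1cc(C(=O)C(=O)Nc2ccc(OC)nc2)c2ccccc21` gives 219 nM in this assay, the lowest of the two numbers available, and the step of a 19-fold lower number from compound 1 to compound 2 (1.28 log units; beyond the scatter) separates it from compound 1. Compound 3 `COc1ccc2c(C(=O)C(=O)Nc3ccc(OC)nc3)cn(C(C)C)c2c1` returns only a limit in this assay, > 10000 nM, and that limit is the limit of > 10000 nM in this assay, at which 1 of the 3 values shown sits.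

Compound 4 `CCCCn1cc(C(=O)C(=O)Nc2ccc(OC)nc2)c2ccccc21` has not yet been measured. Its difference from compound 2 is ethyl in place of hydrogen on a saturated chain carbon, two bonds along the chain from an aromatic nitrogen, so that the ethyl on the indole nitrogen becomes butyl. Among the measured compounds shown here, none of the measured steps touches this chain: the only step available, from compound 1 to compound 2, changes the pyridine on the amide nitrogen, and compound 3 differs from compound 2 in more than one place, so it cannot be read as a single step. For the measured compounds named here, there is therefore no direct precedent for lengthening the chain, and the expectation is a step of a 1.4-fold higher number from compound 2 to compound 4 (0.14 log units; within the scatter) that stays within the usual scatter. Compound 4 is estimated at 300 nM in this assay, with a range from 100 nM to 1200 nM.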

Compound 4, concentration lethal to 50% of the cells: 18 nM
Compound 4: middle estimate off by 17-fold (1.22 log units), on the high side; measured number below the stated range.
By their numbers in this assay, from the lowest: compound 4; then compound 2; then compound 1. At a limit, above all of these: compound 3.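

Changing ethyl to butyl on the aromatic nitrogen gives a 12-fold lower number from compound 2 to compound 4 (1.09 log units; beyond the scatter) in this assay, so this chain is a position where a single change of two carbons has a large effect on the number. Among the compounds shown here, until now the only step that could be read lay at the other end of the molecule, in the methoxypyridine on the amide-type nitrogen, a 19-fold lower number from compound 1 to compound 2 (1.28 log units; beyond the scatter), and the chain now proves to carry a large step of its own. Nothing among the data shown explains why butyl gives the lower number.

As far as these compounds go, with only ethyl and butyl to compare on this nitrogen, it remains open whether propyl falls on the way between them, whether a longer chain such as hexyl lowers the number further, whether a chain ending in an amine or a carboxylic acid keeps the effect, and whether butyl does the same with the 2-methoxypyridin-4-yl group of compound 1. Compound 3 differs from compound 2 in more than one place, so it cannot be read as a step and leaves the branched chain unresolved. The value of compound 3 is a limit, > 10000 nM.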